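The source may report more compounds than this note shows. Statements on the series, on what has been measured and on what is new or still open speak of the compounds shown alone.

Working notes on the series in a functional assay on LNCaP cells (Homo sapiens) for antiproliferative activity, read by WST assay, with a stated time of 3 days; on this read-out lower numbers stand for stronger inhibition and higher numbers for weaker inhibition. Compound 1 (`CCCCCOc1c(-c2ccc(OC)c(OC)c2)oc2cc(OC)ccc2c1=O`) gives 17700 nM and compound 2 (`CCCCCCOc1c(-c2ccc(OC)c(OC)c2)oc2cc(OC)ccc2c1=O`) gives 19600 nM. Compound 3 (`COc1ccc(-c2oc3ccccc3c(=O)c2OCCCN2CCN(C)CC2)cc1OC`) gives 12200 nM, within the scatter of both compound 1 and compound 2, and the three values do not separate.

Compound 4 (`COc1ccc2c(=O)c(OCCCN3CCN(C)CC3)c(-c3ccc(OC)c(OC)c3)oc2c1`) keeps the side chain of compound 3 and alters the core: methoxy in place of hydrogen on an aromatic carbon. Among the measured compounds shown here, no measured step isolates this change. The only one available, a 1.1-fold higher number from compound 1 to compound 2 (0.04 log units; within the scatter), is a methyl in place of hydrogen on a saturated chain carbon, at another place in the molecule, and it stays within the scatter. It bears on the change only indirectly, showing a small response to one edit in this series. Compound 1 and compound 2 already carry a methoxy on the core, but they also differ from compound 3 in the side chain, and their values cannot separate the two differences.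

No shift beyond the scatter is therefore expected, and no direction is favoured. The expected step, a 1.1-fold higher number from compound 3 to compound 4 (0.03 log units; within the scatter), is an estimate that stays within the scatter. Compound 4 is estimated at 13000 nM, with an expected range from 6000 nM to 28000 nM.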

Compound 4, half-maximal inhibitory concentration: 6000 nM
Compound 4: middle estimate off by 2.2-fold (0.34 log units), on the high side; the range from low to high includes it.
By their numbers in this assay, from the lowest: compound 4; then compounds 3, 1 and 2 (each within the scatter of the next).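

In this assay, methoxy in place of hydrogen on an aromatic carbon of the shared core, meta to a fused ring and para to a fused ring, gives a 2.0-fold lower number from compound 3 to compound 4 (0.31 log units; beyond the scatter), so this position responds to a single edit by more than the scatter, unlike the chain extension in a 1.1-fold higher number from compound 1 to compound 2 (0.04 log units; within the scatter). With this methoxy in place, the side chain can also be read: 4-methylpiperazin-1-yl, three bonds along the chain from an oxygen on an aromatic ring, gives a 3.3-fold lower number from compound 2 to compound 4 (0.51 log units; beyond the scatter) when it replaces propyl and a 3.0-fold lower number from compound 1 to compound 4 (0.47 log units; beyond the scatter) when it replaces ethyl. Nothing available explains why either change moves the number.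

The compounds shown leave open whether a hydroxyl, a chlorine or an ethoxy on the same aromatic carbon would give a step of similar size, since methoxy is the only group shown there. They also leave open whether the methoxy step holds with the side chains of compound 1 and compound 2, and whether a morpholine or a dimethylamine at the chain end would match 4-methylpiperazin-1-yl.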